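The source may report more compounds than this note shows. Statements on the series, on what has been measured and on what is new or still open speak of the compounds shown alone.

Measured compounds:
compound 1, `O=C(Nc1cc(Sc2ncn[nH]2)c(O)c2ccccc12)c1cccc([N+](=O)[O-])c1`, 48000 nM
compound 2, `O=C(Nc1cc(Sc2ncnc3nc[nH]c23)c(O)c2ccccc12)c1ccc(Cl)cc1`, 23000 nM
compound 3, `O=C(Nc1cc(Sc2ncn[nH]2)c(O)c2ccccc12)c1cccc(Cl)c1`, > 100000 nM

All three were tested in a functional assay on MDA-MB-231 cells (Homo sapiens) for antiproliferative activity, read by MTT assay, with a stated time of 48 h; a higher number here means a weaker inhibitor, a lower number a stronger inhibitor. For compound 3 the reading is a limit of the assay, not a number. Compound 1 differs from compound 3 by nitro in place of chloro on an aromatic carbon, and this gives an at least 2.0-fold lower number from compound 3 to compound 1 (0.31 log units; beyond the scatter); the step is counted from a limit because compound 3 sits at the limit of > 100000 nM in this assay, at which 1 of the 3 values shown sits. Compound 2 holds the lower of the two numbers that were obtained; how its core differs from that of compound 3 is not broken down here.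

Compound 4, `O=C(Nc1cc(Sc2ncnc3nc[nH]c23)c(O)c2ccccc12)c1ccc([N+](=O)[O-])cc1`, has not yet been measured in this assay. It differs from compound 2 by nitro in place of chloro on an aromatic carbon. Among the measured compounds shown here, this is the same kind of change as the one from compound 3 to compound 1, but the place differs: there the new group sits meta to a large group, here para to a large group. The step is expected to run in the same direction, a 1.9-fold lower number from compound 2 to compound 4 (0.28 log units; within the scatter), resting on the step of an at least 2.0-fold lower number from compound 3 to compound 1 (0.31 log units; beyond the scatter) seen for compound 1. Compound 4 is therefore estimated at 12000 nM, most likely between 5000 nM and 40000 nM.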

Compound 4, half-maximal inhibitory concentration: > 100000 nM
Compound 4: a limit, no number; the forecaster's own chance of this, stated with the estimate: 10%; middle value at least 8.3-fold (0.92 log units) from the limit.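

In this assay compound 4 gives > 100000 nM, which is a limit of the assay and not a number. Nitro in place of chloro yields an at least 4.3-fold higher number from compound 2 to compound 4 (0.63 log units; beyond the scatter), so the change does not keep its direction from one core to the other in this series: the same change on two cores in this assay, an at least 2.0-fold lower number (0.31 log units; beyond the scatter) from compound 3 to compound 1 and an at least 4.3-fold higher number (0.63 log units; beyond the scatter) from compound 2 to compound 4, at least 9.0-fold (0.95 log units) apart, beyond the scatter of two such steps. As far as these compounds go, this does not show that the core alone decides the direction, for the two pairs differ both in their core and in where the new group sits on the aromatic ring, and the true size of each step stays unknown, as each is counted from a limit.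

Left open is how nitro and chloro would compare at one and the same place on each of the two cores. Also open, from the compounds shown here alone, is whether an amine or a carboxylic acid in place of chloro would follow either step, and how the 4-chlorophenyl and 4-nitrophenyl amides would read with other groups on the sulfur.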